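The compounds below may be only part of what the source reports. "The series", "measured", "known", "first", "only" and "open" are said of these compounds alone.

Compounds measured so far:
- Compound 1 `COc1ccc(C2=C(c3ccc(SC)cc3)CC3CCCN3C2=O)cc1Br`: 3000 nM
- Compound 2 `CSc1ccc(C2=C(c3ccc(F)c(C)c3)C(=O)N3CCCC3C2)cc1`: 800 nM

In a functional assay on M14 cells (Homo sapiens) for cytotoxicity (a higher number here means a weaker inhibitor of growth, a lower number a stronger inhibitor of growth), compound 2 has the lower of the two numbers, 800 nM. Compound 3 `CSc1ccc(C2=C(c3ccc(O)cc3)C(=O)N3CCCC3C2)cc1` is unmeasured and has 4-hydroxyphenyl in place of 4-fluoro-3-methylphenyl on a double-bonded ring carbon. Going by the values given here, only one measured step bears on this, a change at the same carbon: a 3.8-fold lower number from compound 1 to compound 2 (0.57 log units; beyond the scatter). That modest step shows that this group can matter, but neither compound carries 4-hydroxyphenyl. A similarly modest rise is therefore expected, though with little certainty about its direction. The expected step is a 2.5-fold higher number from compound 2 to compound 3 (0.40 log units; beyond the scatter). The estimate for compound 3 is 2000 nM, with a range of 500 nM to 8000 nM.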

Compound 3, concentration for 50% growth inhibition: > 100000 nM
Compound 3: a limit, no number (the forecaster's own chance of this, stated with the estimate: 3%); at least 50-fold (1.69 log units) between middle value and limit.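

In this assay compound 3 gives > 100000 nM, which is a limit of the assay and not a number. The earlier compounds shown here showed only a modest effect at this carbon, but 4-hydroxyphenyl brings an at least 120-fold higher number from compound 2 to compound 3 (2.09 log units; beyond the scatter) and also an at least 33-fold higher number from compound 1 to compound 3 (1.52 log units; beyond the scatter), so this one group can nearly abolish growth inhibition. The full size of both steps stays unknown because they rest on a limit: the limit of > 100000 nM in this assay, at which 1 of the 3 values shown sits.

The compounds shown cannot separate the effect of gaining the hydroxyl from that of losing the fluorine and methyl. As far as these compounds go, it also remains open how a plain phenyl or a 4-aminophenyl group would behave at this carbon.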